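This account rests on a few compounds, and the source may have more. Where it says the series, first, only, none or still open, it means among the compounds named here.

Measured compounds:
- compound 1 `CC/N=C(\S)NCCCn1nc(-c2ccccc2)ccc1=O` — 39%
- compound 2 `C=CCNC(=S)NCCCCn1nc(-c2ccccc2)ccc1=O` — 27.1%
- compound 3 `C/N=C(\S)N(C)CCCCn1nc(-c2ccccc2)ccc1=O` — 17.5%

In a functional assay on the whole organism with Rattus norvegicus as the target, at a dose of 100 mg/kg (on this read-out higher numbers stand for more inhibition at the one dose given (going by the name of the read-out) and lower numbers for less inhibition), compound 3 stands lowest of the three numbers. Against compound 2 the gap is a number 9.6 percentage points lower from compound 2 to compound 3 (within the scatter), within the scatter, so the two cannot be ordered; against compound 1 the gap is a number 21.5 percentage points lower from compound 1 to compound 3 (beyond the scatter), beyond the scatter.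

Compound 4 `C/N=C(\S)NCCCCn1nc(-c2ccccc2)ccc1=O` differs from compound 3 in one place: hydrogen in place of methyl on an amine nitrogen.

For the measured compounds named here, no measured step isolates this change. The step of a number 9.6 percentage points lower from compound 2 to compound 3 (within the scatter) contains it in the reverse direction, together with a second change on the other side of the same group, and it lies within the scatter; the step of a number 11.9 percentage points lower from compound 1 to compound 2 (beyond the scatter) alters a different group and does not bear on the amine nitrogen. The evidence therefore points to no step beyond the scatter for compound 4 relative to compound 3, with any movement more likely upward than downward. The expected step is a number 5.5 percentage points higher from compound 3 to compound 4 (within the scatter).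

Compound 4 is estimated at 23%, within 10% to 36%.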

Compound 4, a percentage reported as inhibition, in the whole organism at one dose (the size of the read-out at that dose, not a potency): 87.1%
Compound 4: the middle estimate sits 64.1 percentage points below what was measured, and the stated range ends below it.
By their numbers in this assay, from the lowest: compounds 3 and 2 (each within the scatter of the next); then compound 1; then compound 4.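

In this assay, for the compounds shown here, the amine nitrogen proves far more sensitive than the earlier compounds suggested: hydrogen in place of methyl gives a number 69.6 percentage points higher from compound 3 to compound 4 (beyond the scatter) and is the largest step. Compound 4 also stands clear of the other two, with a number 60 percentage points higher from compound 2 to compound 4 (beyond the scatter) for the smaller group on the amine nitrogen and a number 48.1 percentage points higher from compound 1 to compound 4 (beyond the scatter) for the exchange of one group of 6 heavy atoms for another on a saturated chain carbon, which makes it the highest of the four at this dose. Nothing at hand accounts for the size of this jump.

Open, from the compounds shown here alone, is whether hydrogen in place of methyl gives a similar step on a chain of another length, as it is seen here in one pair only. Also open, going by these compounds, is how a benzyl group on the amine nitrogen or a longer chain would read in this assay.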